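Terphenyl benzimidazoles: trifluoromethoxy to hydroxy on the outer ring

This account rests on a few compounds, and the source may have more. Where it says the series, first, only, none or still open, it means among the compounds named here.

Three compounds in this series share a terphenyl chain capped by a benzimidazole and carry a variable group on the far ring. Compound 1 `Oc1cccc2[nH]c(-c3ccc(-c4ccc(-c5ccc(OC(F)(F)F)cc5)cc4)cc3)nc12` gives 3800 nM in a functional assay on ZR-75-1 cells (Homo sapiens) for inhibition, read by sulforhodamine B assay; a lower number here means a stronger inhibitor of growth, a higher number a weaker inhibitor of growth. Compound 2 `Oc1ccc(-c2ccc(-c3ccc(-c4nc5c(O)cccc5[nH]4)cc3)cc2)cc1` gives 2650 nM in this assay. Compound 3 `Cc1ccc2[nH]c(-c3ccc(-c4ccc(-c5ccc(OC(F)(F)F)cc5)cc4)cc3)nc2c1` gives 2410 nM in this assay. The change from compound 1 to compound 2 is hydrogen in place of trifluoromethyl on an oxygen on an aromatic ring and made a step of a 1.4-fold lower number from compound 1 to compound 2 (0.16 log units; within the scatter). The two cores differ as 5-methyl-1H-benzimidazol-2-yl in place of 4-hydroxy-1H-benzimidazol-2-yl on an aromatic carbon, with a step of a 1.6-fold lower number from compound 1 to compound 3 (0.20 log units; within the scatter). Compound 3 has the lowest number of the three, but its gaps to compound 2 and to compound 1 are both within the scatter, so no order among them is claimed.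

Compound 4 `Cc1ccc2[nH]c(-c3ccc(-c4ccc(-c5ccc(O)cc5)cc4)cc3)nc2c1` is not yet measured in this assay. It differs from compound 3 by hydrogen in place of trifluoromethyl on an oxygen on an aromatic ring. This is the same change as that from compound 1 to compound 2, and the surroundings of the place are the same in both pairs. Within the data shown here, the single earlier example of it, a step of a 1.4-fold lower number from compound 1 to compound 2 (0.16 log units; within the scatter), is within the scatter, so a similarly small step is expected from compound 3 to compound 4, namely a 1.4-fold lower number from compound 3 to compound 4 (0.15 log units; within the scatter), resting on that one pair alone. Compound 4 is therefore estimated at 1700 nM in this assay, with a range from 800 nM to 3600 nM.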

Compound 4, concentration for 50% growth inhibition: 18200 nM
For compound 4 the middle estimate is 11-fold (1.03 log units) below the measured one; the whole stated range lies below it.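

In this assay the change from trifluoromethoxy to hydroxy does not behave alike on the two cores, so the size of the step on one core cannot be carried over to the other in this series: the same change on two cores in this assay, a 1.4-fold lower number (0.16 log units; within the scatter) from compound 1 to compound 2 and a 7.6-fold higher number (0.88 log units; beyond the scatter) from compound 3 to compound 4, 11-fold (1.03 log units) apart, beyond the scatter of two such steps.

On the core of compound 3 the change gives a 7.6-fold higher number from compound 3 to compound 4 (0.88 log units; beyond the scatter) and so weakens growth inhibition, whereas on the core of compound 1 it gives a 1.4-fold lower number from compound 1 to compound 2 (0.16 log units; within the scatter) and no change can be claimed. The result shows that the step depends on the core, but it rests on a single pair per core, so it does not show which feature of the 5-methyl-1H-benzimidazol-2-yl or 4-hydroxy-1H-benzimidazol-2-yl core is responsible, or how the change would behave on any third core.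

The compounds shown leave open how the terminal position responds to anything other than trifluoromethoxy and hydroxy, such as a methoxy group, an amine or a carboxylic acid. They also leave open whether the same change on an unsubstituted benzimidazole, or on one bearing a chlorine atom, would follow the step on the core of compound 1 or the step on the core of compound 3.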